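From a Sulfonamide to an Acetamide on a Shared Core

This account rests on a few compounds, and the source may have more. Where it says the series, first, only, none or still open, it means among the compounds named here.

Compound 1 `CC(C)S(=O)(=O)Nc1cccc2c1CCCC2c1c[nH]cn1` is known in an assay on isolated protein (Cricetulus griseus) for binding affinity to Alpha-1B adrenergic receptor (Mesocricetus auratus), read by radioligand binding (a lower number here means a stronger inhibitor, a higher number a weaker inhibitor), only as a limit, < 10000 nM. Compound 2 `CN(C)S(=O)(=O)Nc1cccc2c1CCCC2c1c[nH]cn1` likewise stands at a limit in this assay, < 10000 nM. The step that the two limits leave unreadable from compound 1 to compound 2 therefore cannot be read, since the limit of < 10000 nM in this assay, at which 2 of the 2 values shown sit, holds both values. Compound 3 `CC(=O)Nc1cccc2c1CCCC2c1c[nH]cn1` departs from compound 2 by acetyl in place of dimethylsulfamoyl on a nitrogen on an aromatic ring, the dimethylsulfamoyl group giving way to acetyl. Among the compounds with values here, no measured step bears on this change, so no direction can be expected beyond the scatter. Compound 3 is estimated at 1000 nM, within 100 nM to 10000 nM, an expected step that the limit leaves unreadable from compound 2 to compound 3 that rests on a guess alone.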

Compound 3, inhibition constant: < 10000 nM
Compound 3: a limit, no number (the forecaster's own chance of this, stated with the estimate: 70%); the middle value lies beyond the limit too.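

No step among compound 1, compound 2 and compound 3 can be read, because all three values are limits: the limit of < 10000 nM in this assay, at which 3 of the 3 values shown sit.

The compounds shown leave open whether changing the group on the nitrogen alters binding strength at all.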